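The source may report more compounds than this note shows. Statements on the series, on what has been measured and on what is new or still open speak of the compounds shown alone.

Working notes on the series. The reference point is compound 1 `O=S(=O)(c1ccccc1)n1ccc2c(O)cccc21`, which in an assay on isolated protein for displacement of a labelled ligand from 5-hydroxytryptamine receptor 6 (Homo sapiens), read by scintillation counting, with a stated time of 1 h (on this read-out lower numbers stand for stronger inhibition and higher numbers for weaker inhibition), gives 108 nM. Compound 2 `CC(=O)N1CCN(c2ccc3c(ccn3S(=O)(=O)c3ccccc3)c2)CC1` carries the 4-acetylpiperazin-1-yl group on the six-membered carbon ring of the shared core; in this assay compound 2 gives 4850 nM, the highest of the two numbers recorded so far, and the gap to compound 1 is beyond the scatter. Going by the values given here, no step between measured compounds can be written for this pair, since the two structures differ in more than one place; only the two values themselves can be compared.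

Compound 3 `CN(C)c1ccc2c(ccn2S(=O)(=O)c2ccccc2)c1` is the next member, not yet measured. Among the compounds with values here, its single change from compound 2 is dimethylamino in place of 4-acetylpiperazin-1-yl on an aromatic carbon. Within the data shown here, the series holds no measured step of this kind, so the expectation rests only on the two recorded values and the structural change. The step from compound 2 to compound 3 is expected to be an 8.1-fold lower number from compound 2 to compound 3 (0.91 log units; beyond the scatter), a move towards the stronger end. For compound 3 the estimate in this assay is 600 nM, within a range from 120 nM to 3000 nM.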

Compound 3, inhibition constant: 82 nM
Compound 3: the middle estimate sits 7.3-fold (0.86 log units) above what was measured; measured number below the stated range.
By their numbers in this assay, from the lowest: compounds 3 and 1 (each within the scatter of the next); then compound 2.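

At this aromatic carbon of the shared core, this assay proves highly sensitive to the substituent: dimethylamino in place of 4-acetylpiperazin-1-yl gives a 59-fold lower number from compound 2 to compound 3 (1.77 log units; beyond the scatter), a large step and the first single-place change readable in the series. The high number of compound 2 therefore does not come from substitution at this carbon as such, since compound 3 carries an amino group at the same place. Nothing at hand accounts for the size of this step.

The step removes the six-membered non-aromatic ring and the acetyl carbonyl together, and the heavy atom count falls from 9 to 3, so these changes cannot be told apart. The compounds shown leave open how an unacetylated piperazin-1-yl group, a pyrrolidin-1-yl ring or a simple methoxy group would read at this carbon.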